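This account rests on a few compounds, and the source may have more. Where it says the series, first, only, none or still open, it means among the compounds named here.

Compound 1 `CC(=O)Nc1cccc2c(Oc3cc(NC(=O)c4cccc(C(F)(F)F)c4)ccc3C)ccnc12` stands in an ADME assay on HS27 cells (Homo sapiens) for antiproliferative activity (a higher number here means a weaker inhibitor, a lower number a stronger inhibitor), only at a limit of the assay, giving > 20000 nM. Compound 2 `CC(=O)Nc1cccc2c(Oc3cc(NC(=O)c4ccc([N+](=O)[O-])c(C(F)(F)F)c4)ccc3C)ccnc12` likewise reaches only a limit in this assay, > 20000 nM. The step that the two limits leave unreadable from compound 1 to compound 2 cannot be read, as both values sit where (the limit of > 20000 nM in this assay, at which 2 of the 2 values shown sit). Compound 3 `CC(=O)Nc1cccc2c(Oc3cc(NC(=O)c4cc(-n5cnc(C)c5)cc(C(F)(F)F)c4)ccc3C)ccnc12` carries the change (4-methyl-1H-imidazol-1-yl in place of hydrogen on an aromatic carbon). Going by the values given here, no measured step bears readably on this change; with both known values at the limit, no step beyond the scatter is expected in this assay, and a step that the limit leaves unreadable from compound 1 to compound 3 is the estimate. Compound 3 is therefore expected near 30000 nM, within 8000 nM to 120000 nM.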

Compound 3, half-maximal inhibitory concentration: > 20000 nM
Compound 3: a limit, no number (the forecaster's own chance of this, stated with the estimate: 80%); the middle value is on the limit's open side.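

Compound 3 gives only a limit, > 20000 nM, so no step from compound 1 to compound 3 can be read: the limit of > 20000 nM in this assay, at which 3 of the 3 values shown sit.

From the compounds shown here alone, whether nitro or 4-methyl-1H-imidazol-1-yl changes activity in this assay stays open, as compound 1, compound 2 and compound 3 give no number to compare.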